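Replacing 4-fluorophenyl with 2,6-dimethoxyphenyl on the shared core

The source may hold more compounds than are shown below. What is called first, only, known or untested is meant among the compounds shown, and "the series" means these compounds.

Among the compounds with values here, in a functional assay on DU-145 cells (Homo sapiens) for inhibition, read by trypan blue exclusion, with a stated time of 96 h (on this read-out higher numbers stand for weaker inhibition of growth and lower numbers for stronger inhibition of growth), compound 3 (`O=C(/C(=C\c1ccc(F)cc1)S(=O)(=O)c1ccc(Br)cc1)c1ccc(Br)cc1`) gives 4000 nM, the lower of the two actual numbers so far. Compound 2 (`O=C(/C(=C\c1ccc(Cl)c([N+](=O)[O-])c1)S(=O)(=O)c1ccc(Br)cc1)c1ccc(Br)cc1`) gives 10000 nM. Compound 1 (`COc1cc(OC)c(/C=C(\C(=O)c2ccc(Br)cc2)S(=O)(=O)c2ccc(Br)cc2)c(OC)c1`), which also carries methoxy groups at the place in question, gives > 100000 nM, a limit of the assay and not a number.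

Compound 4 (`COc1cccc(OC)c1/C=C(\C(=O)c1ccc(Br)cc1)S(=O)(=O)c1ccc(Br)cc1`) has yet to be measured in this assay. Its change from compound 3 is 2,6-dimethoxyphenyl in place of 4-fluorophenyl on a double-bonded chain carbon bound to a double-bonded chain carbon. Within the data shown here, the only measured step at this place is a 2.5-fold lower number from compound 2 to compound 3 (0.40 log units; beyond the scatter), which is modest in size. That step and the limit seen for compound 1 both bear on the change, though neither measures it directly. A higher number, meaning weaker inhibition of growth, is therefore expected, and the expected step is a 6.3-fold higher number from compound 3 to compound 4 (0.80 log units; beyond the scatter), larger than the modest measured one. For compound 4 the estimated value is 25000 nM, with an expected range of 6000 nM to 100000 nM.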

Compound 4, concentration for 50% growth inhibition: 10000 nM
Estimate against measurement, compound 4: 2.5-fold (0.40 log units) above; low and high end bracket the measured number.
By their numbers in this assay, from the lowest: compound 3; then compounds 2 and 4 (each within the scatter of the next). At a limit, above all of these: compound 1.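

In this assay, 2,6-dimethoxyphenyl in place of 4-fluorophenyl gives a 2.5-fold higher number from compound 3 to compound 4 (0.40 log units; beyond the scatter), so a methoxy-bearing ring at this place costs only modestly and still yields an actual number. In place of 4-chloro-3-nitrophenyl, the same group gives no change at the digits printed from compound 2 to compound 4 (within the scatter), so this assay does not separate those two groups. Hydrogen in place of methoxy on an aromatic carbon gives an at least 10-fold lower number from compound 1 to compound 4 (1.00 log units; beyond the scatter), a step that starts from a limit of the assay and not a number, so the one methoxy group separates a measurable compound from one at that limit: the limit of > 100000 nM in this assay, at which 1 of the 4 values shown sits.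

The compounds shown leave open how an amine or a carboxylic acid would read at this place. They also leave open whether a ring with a single methoxy group would match 2,6-dimethoxyphenyl.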